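A few compounds are considered here, and "the series" means these few. Any claim that something is new, unique, unknown or untested is made for them only; others in the source may bear on it.

Measured in an ADME assay on MT2 cells (Homo sapiens) for cytotoxicity, read by XTT assay, with a stated time of 4 days; on this read-out higher numbers stand for lower toxicity in this test and lower numbers for higher toxicity in this test:

- Compound 1 `Cc1nc(C(NC(=O)C(=O)Nc2ccc(Cl)c(F)c2)C2CCCCN2)sc1CCO`: > 41000 nM (a limit)
- Compound 2 `CC(=O)N1CCCCC1C(NC(=O)C(=O)Nc1ccc(Cl)cc1)c1nc(C)c(CCO)s1`: > 84000 nM (a limit)
- Compound 3 `Cc1nc(C(NC(=O)C(=O)Nc2ccc(F)c(F)c2)C2CCCCN2)sc1CCO`: > 78200 nM (a limit)

None of these three results is an exact number, so the series has no measured toxic concentration yet. Compound 3 stands at > 78200 nM, which is a limit.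

Compound 4 `Cc1nc(C(NC(=O)C(=O)Nc2ccc(Cl)cc2)C2CCCCN2)sc1CCO` differs from compound 3 in one place: 4-chlorophenyl in place of 3,4-difluorophenyl on an amide-type nitrogen. In words, 4-chlorophenyl sits in place of 3,4-difluorophenyl on an amide-type nitrogen.

For the measured compounds named here, the one measured step close to this change is a step that the two limits leave unreadable from compound 1 to compound 3, which puts fluoro in place of chloro on an aromatic carbon. It gives no size to carry over. Compound 2 also carries the 4-chlorophenyl group, and its > 84000 nM is likewise a limit, although its core differs.

With nothing pointing either way, no change beyond the usual scatter is expected, and the estimated step is an at least 1.1-fold lower number from compound 3 to compound 4 (0.04 log units; that floor lies within the scatter). For compound 4 the expected value is 70000 nM, with an estimated range from 30000 nM to 150000 nM, and it will most likely be reported as a limit again.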

Compound 4, half-maximal cytotoxic concentration: > 62000 nM
Compound 4 was reported as a limit (the forecaster's own chance of this, stated with the estimate: 85%); the middle value lies beyond the limit too.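

In this assay compound 4 gives > 62000 nM, which is a limit. For the compounds shown here, compound 1, compound 2 and compound 3 are also reported only as limits, so no step to compound 4 can be read. The compounds shown leave open the concentration at which any of them harms these cells.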